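Alkyl groups on the ring nitrogen of a benzimidazole series

The source may hold more compounds than are shown below. What is called first, only, known or untested is meant among the compounds shown, and "the series" means these compounds.

Measured compounds:
Compound 1 `CC(C)c1onc(-c2c(Cl)cccc2Cl)c1COc1ccc(-c2nc3ccc(C(=O)O)cc3n2CC(C)(C)C)cc1` — 13 nM
Compound 2 `CC(=O)N1CCC(n2c(-c3ccc(OCc4c(-c5c(Cl)cccc5Cl)noc4C(C)C)cc3)nc3ccc(C(=O)O)cc32)CC1` — 1430 nM
Compound 3 `CCC(CC)n1c(-c2ccc(OCc3c(-c4c(Cl)cccc4Cl)noc3C(C)C)cc2Cl)nc2ccc(C(=O)O)cc21` — 1.6 nM

In an assay on Huh-7 cells for agonist activity at Bile acid receptor (Homo sapiens), read by a luciferase reporter (a lower number here means that less compound is needed, a higher number that more compound is needed for the effect), compound 2 gives 1430 nM, the highest of the three numbers; the nearest is compound 1, and compound 3 lies furthest away. Going by the values given here, the only single-site step involving compound 2 is a 110-fold higher number from compound 1 to compound 2 (2.04 log units; beyond the scatter), where 1-acetylpiperidin-4-yl replaced neopentyl on the aromatic nitrogen. Compound 3 differs from compound 2 in two places, so its number can only be noted beside the others.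

Compound 4 `CCCn1c(-c2ccc(OCc3c(-c4c(Cl)cccc4Cl)noc3C(C)C)cc2)nc2ccc(C(=O)O)cc21` is not yet measured. Its change from compound 2 is propyl in place of 1-acetylpiperidin-4-yl on an aromatic nitrogen. Since compound 1, with neopentyl in that place, gives 13 nM, and compound 3, with 3-pentyl there and a chlorine on the attached phenyl, gives 1.6 nM, a return to a small alkyl chain is expected to reverse most of the large rise seen in the step from compound 1 to compound 2. Compound 4 is therefore expected to show a large drop in this assay, of about a 48-fold lower number from compound 2 to compound 4 (1.68 log units; beyond the scatter). The estimated value of compound 4 is 30 nM, with a range from 8 nM to 120 nM.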

Compound 4, half-maximal effective concentration: 9.3 nM
For compound 4 the middle estimate is 3.2-fold (0.51 log units) above the measured one, and the stated range covers the measured number.
By their numbers in this assay, from the lowest: compound 3; then compounds 4 and 1 (each within the scatter of the next); then compound 2.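

In this assay the exchange of 1-acetylpiperidin-4-yl for propyl on the aromatic nitrogen gives a 150-fold lower number from compound 2 to compound 4 (2.19 log units; beyond the scatter), so among these compounds the high number goes with that one group and not with alkyl substitution at this position as such. The comparison with the neopentyl compound gives a 1.4-fold lower number from compound 1 to compound 4 (0.15 log units; within the scatter), which shows that the tert-butyl end of that chain is not required for a low number here. No measurement given here explains either step.

As far as these compounds go, whether a cyclohexyl ring, a free piperidine amine or a longer chain on this nitrogen would keep the low number stays open, as does which part of the 1-acetylpiperidin-4-yl group goes with the high number. The chlorine of compound 3 also cannot be judged alone, since it appears only together with a 3-pentyl group.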